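Lengthening the aryl side chain of compound 3

The source may report more compounds than this note shows. Statements on the series, on what has been measured and on what is new or still open speak of the compounds shown alone.

Compound 3 `NCCCCCC(C[Se]C(=O)CCc1ccccc1)C(=O)O` stands second highest of the three numbers in an assay on isolated protein for inhibition of carboxypeptidase B2 (Homo sapiens), read by spectrophotometry, with stated times of 10 min and 30 min (on this read-out lower numbers stand for stronger inhibition and higher numbers for weaker inhibition), at 2000 nM. Compound 2 `CCOC(=O)C(CCCCCN)C[Se]C(=O)CC` gives 1400 nM in this assay, within the scatter of that figure, while compound 1 `CCOC(=O)C(CCCCCN)CSC(C)=O` gives 310000 nM. Among the compounds with values here, the only step between measured compounds, a 220-fold lower number from compound 1 to compound 2 (2.35 log units; beyond the scatter), concerns a different part of the chain and does not bear on a change of the aryl group. Compound 4 `NCCCCCC(C[Se]C(=O)CCCc1ccccc1)C(=O)O` differs from compound 3 by benzyl in place of phenyl on a saturated chain carbon, two bonds along the chain from a carbonyl carbon. Within the data shown here, with no measured step of this kind to draw on, no move beyond the scatter is expected, so the expected step of no change at the digits printed from compound 3 to compound 4 (within the scatter) is small. Compound 4 is therefore estimated at 2000 nM in this assay, with a range from 700 nM to 6000 nM.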

Compound 4, half-maximal inhibitory concentration: 1600 nM
For compound 4 the middle estimate is 1.3-fold (0.10 log units) above the measured one, and the stated range covers the measured number.
By their numbers in this assay, from the lowest: compounds 2, 4 and 3 (each within the scatter of the next); then compound 1.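

In this assay, benzyl in place of phenyl on a saturated chain carbon, two bonds along the chain from a carbonyl carbon, gives a 1.3-fold lower number from compound 3 to compound 4 (0.10 log units; within the scatter) and so no move beyond the scatter. The earlier compounds shown here held no step in the aryl group at this place; this one shows that the number holds when benzyl enters for phenyl. Nothing measured here explains why the number holds.

On these data alone, whether a longer chain, such as 2-phenylethyl, would also leave the number in place stays open. So does the effect of an amine or a carboxylic acid on the aromatic ring.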